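Cyano in place of methyl: expected tolerance of compound 4

The source may hold more compounds than are shown below. What is called first, only, known or untested is meant among the compounds shown, and "the series" means these compounds.

Compound 1 `Cc1ccnc(OC(c2ccc(C(F)(F)F)cc2)C2CCN(C(C)CCNC(=O)c3c(Cl)cncc3Cl)CC2)c1` gives 33600 nM in an ADME assay on PBMC cells (Homo sapiens) for cytotoxicity; a higher number here means that more compound is tolerated, a lower number that less compound is tolerated.
Compound 2 `COc1cccc(OC(c2ccc(C(F)(F)F)cc2)C2CCN(C(C)CCNC(=O)c3c(Cl)cncc3Cl)CC2)n1` gives 32700 nM in this assay.
Compound 3 `Cc1cccc(OC(c2ccc(C(F)(F)F)cc2)C2CCN(C(C)CCNC(=O)c3c(Cl)cncc3Cl)CC2)n1` gives 6700 nM in this assay.

Among these three, compound 3 stands at the lowest number in this assay, with the other two both beyond the scatter from it: a 4.9-fold lower number from compound 2 to compound 3 (0.69 log units; beyond the scatter), and a 5.0-fold lower number from compound 1 to compound 3 (0.70 log units; beyond the scatter). The first of those two steps is a change on the same aromatic carbon, methoxy giving way to methyl, while the second moves the methyl from one aromatic carbon to another. Compound 1 and compound 2 themselves sit within the scatter of each other: a 1.0-fold lower number from compound 1 to compound 2 (0.01 log units; within the scatter).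

Compound 4 `CC(CCNC(=O)c1c(Cl)cncc1Cl)N1CCC(C(Oc2cccc(C#N)n2)c2ccc(C(F)(F)F)cc2)CC1` differs from compound 3 in one place: cyano in place of methyl on an aromatic carbon. For the measured compounds named here, no measured step involves a cyano group, so the only guide is that replacing the group on this aromatic carbon has already moved the number once, and that compound 3 holds the lowest value of the set. A return toward the numbers of compound 1 and compound 2 is therefore the more likely outcome, though not a certain one, and the expected step is a 2.2-fold higher number from compound 3 to compound 4 (0.35 log units; beyond the scatter). Compound 4 is thus estimated at 15000 nM in this assay, with a range from 6000 nM to 40000 nM.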

Compound 4, half-maximal cytotoxic concentration: 15700 nM
The estimate for compound 4 lay 1.0-fold (0.02 log units) below the measured number; low and high end bracket the measured number.
By their numbers in this assay, from the lowest: compound 3; then compound 4; then compounds 2 and 1 (each within the scatter of the next).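

In this assay, for the compounds shown here, a 2.3-fold higher number from compound 3 to compound 4 (0.37 log units; beyond the scatter) and a 2.1-fold lower number from compound 2 to compound 4 (0.32 log units; beyond the scatter) together give three distinct levels for the group on the aromatic carbon next to the ring nitrogen, where the earlier compounds offered only the contrast between methoxy and methyl. Cyano therefore falls between those two groups, so the position does not behave as a simple switch between a high and a low level, and the shift with a 2.1-fold lower number from compound 1 to compound 4 (0.33 log units; beyond the scatter) shows that the 6-cyanopyridin-2-yl compound also stays apart from the 4-methylpyridin-2-yl compound, rather than joining it as the methoxy compound does. Nothing in the data shown accounts for this order of methyl, cyano and methoxy at this carbon.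

The compounds shown leave open where other groups on this same carbon would fall relative to these three levels, for example a chlorine, an amine, a carboxylic acid or a longer chain such as ethoxy. They also leave open whether cyano on the carbon that carries the methyl in compound 1 would give a number like that of compound 4 or a different one.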